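A few compounds are considered here, and "the series" means these few. Any claim that something is new, unique, unknown or untested is made for them only; others in the source may bear on it.

Working notes on the series, continued.

Going by the values given here, compound 3 `CC(=O)Oc1ccc(-c2ccc(F)cc2F)cc1C(=O)Nc1ccccc1Cl` stands highest of the three numbers so far in a functional assay on the whole organism (Ear) for inhibition, with Mus musculus as the target, at a dose of 40 mg/kg by the oral route (on this read-out higher numbers stand for more inhibition at the one dose given (going by the name of the read-out) and lower numbers for less inhibition), at 41.4%. Compound 1 `CC(=O)Oc1ccc(-c2ccc(F)cc2F)cc1C(=O)NCc1ccccc1` gives 34.1% in this assay, and compound 2 `CC(=O)Oc1ccc(-c2ccc(F)cc2F)cc1C(=O)Nc1ccccc1` gives 23.2%. Among the compounds with values here, the steps run a number 10.9 percentage points lower from compound 1 to compound 2 (beyond the scatter), a number 7.3 percentage points higher from compound 1 to compound 3 (within the scatter) and a number 18.2 percentage points higher from compound 2 to compound 3 (beyond the scatter); only the last two separate compound 3 from its neighbours, and only the one from compound 2 lies beyond the scatter.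

Compound 4 `CC(=O)Oc1ccc(-c2ccc(F)cc2F)cc1C(=O)Nc1ccc(Cl)cc1` is the next to be measured. The change from compound 3 to compound 4 is 4-chlorophenyl in place of 2-chlorophenyl on an amide-type nitrogen. Within the data shown here, no measured step moves a chloro substituent from one position of the ring to another; the nearest bearing is the chloro-for-hydrogen step from compound 2 to compound 3, which was modest. Whether that gain survives at the new position is open, so the expected step is a number 8.4 percentage points lower from compound 3 to compound 4 (within the scatter), within the scatter. Compound 4 is therefore estimated at 33% in this assay, with a range from 18% to 48%.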

Compound 4, a percentage reported as inhibition, in the whole organism at one dose (the size of the read-out at that dose, not a potency): 0%
Estimate against measurement, compound 4: 33 percentage points above, outside the stated range (below it).
By their numbers in this assay, from the lowest: compound 4; then compound 2; then compounds 1 and 3 (each within the scatter of the next).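

In this assay, going by these compounds alone, the two compounds carry the same atoms, yet the step of a number 41.4 percentage points lower from compound 3 to compound 4 (beyond the scatter) is the largest so far, so the position of the chloro on the phenyl on the amide-type nitrogen matters here, not only its presence. Chloro in place of hydrogen now reads in both directions: the step of a number 18.2 percentage points higher from compound 2 to compound 3 (beyond the scatter) stands against the step of a number 23.2 percentage points lower from compound 2 to compound 4 (beyond the scatter) for the 4-chlorophenyl, which also gives the step of a number 34.1 percentage points lower from compound 1 to compound 4 (beyond the scatter) against the benzyl of compound 1. No measurement at hand explains this dependence on position.

On these data alone, whether a methoxyphenyl or a bromophenyl on the amide-type nitrogen shows the same split between its 2- and 4-substituted forms remains open. So does whether a chlorobenzyl group in place of the benzyl of compound 1 shows it.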